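Acetamido in place of trifluoromethoxy on a carboxamide core

The source may report more compounds than this note shows. Statements on the series, on what has been measured and on what is new or still open speak of the compounds shown alone.

Compound 1 `CC(=O)Nc1ccc(Oc2cncc3sc(-c4nnn[nH]4)cc23)cc1`: 2 nM
Compound 2 `COc1ccc(Oc2cncc3sc(C(N)=O)cc23)cc1`: 25 nM
Compound 3 `NC(=O)c1cc2c(Oc3ccc(OC(F)(F)F)cc3)cncc2s1`: 12 nM

In an assay for inhibition of CDK8/Cyclin C (Homo sapiens), read by fluorescence polarization (on this read-out higher numbers stand for weaker inhibition and lower numbers for stronger inhibition), compound 3 gives 12 nM, the second highest of the three numbers; compound 2 gives 25 nM and compound 1 gives 2 nM. Among the measured compounds shown here, the one single-point step measured is a 2.1-fold lower number from compound 2 to compound 3 (0.32 log units; beyond the scatter). Compound 4 `CC(=O)Nc1ccc(Oc2cncc3sc(C(N)=O)cc23)cc1` differs from compound 3 by acetamido in place of trifluoromethoxy on an aromatic carbon. For the measured compounds named here, no measured step swaps these two groups directly. Going by the values given here, the only comparison of the group on that aromatic carbon is a 2.1-fold lower number from compound 2 to compound 3 (0.32 log units; beyond the scatter), a modest shift, and compound 1, which also carries the acetamido but a different group on the shared core, gives 2 nM. For compound 4 the expected step is therefore a 1.2-fold lower number from compound 3 to compound 4 (0.08 log units; within the scatter), within the scatter. Compound 4 is estimated at 10 nM, in a range from 3 nM to 40 nM.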

Compound 4, half-maximal inhibitory concentration: 29 nM
Compound 4: the middle estimate sits 2.9-fold (0.46 log units) below what was measured, within the range that was stated.
By their numbers in this assay, from the lowest: compound 1; then compound 3; then compounds 2 and 4 (each within the scatter of the next).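

In this assay, acetamido on this aromatic carbon does not keep the lower number seen with trifluoromethoxy (a 2.4-fold higher number from compound 3 to compound 4 (0.38 log units; beyond the scatter)), and it cannot be told apart from methoxy (a 1.2-fold higher number from compound 2 to compound 4 (0.06 log units; within the scatter)). With acetamido held fixed, changing the group on the shared core gives the largest step (a 15-fold higher number from compound 1 to compound 4 (1.16 log units; beyond the scatter)), so acetamido alone does not account for the low number of compound 1. No measurement here explains these shifts. The compounds shown leave open how an amine or a carboxylic acid on that aromatic carbon would compare, and how trifluoromethoxy would fare with 1H-tetrazol-5-yl on the core.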